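A few compounds are considered here, and "the series" means these few. Any claim that something is new, unique, unknown or untested is made for them only; others in the source may bear on it.

The measured compounds:

Compound 1 `O=C(O)/C=C/c1ccc(Cn2cccn2)cc1OCCc1ccc2ccccc2c1` gives 2900 nM in an assay on CHO cells for displacement of a labelled ligand from prostaglandin E2 receptor EP1 subtype (Mus musculus), read by scintillation counting; on this read-out lower numbers stand for stronger inhibition and higher numbers for weaker inhibition.
Compound 2 `O=C(O)/C=C/c1ccc(COc2ccccc2)cc1OCCc1ccc2ccccc2c1` gives only a limit of > 10000 nM in this assay.

Compound 2 therefore stands at the weak end of what is shown: its value is a limit of the assay, not a measured number (the limit of > 10000 nM in this assay, at which 1 of the 2 values shown sits). Going by the values given here, the one measured step, an at least 3.4-fold higher number from compound 1 to compound 2 (0.53 log units; beyond the scatter), went in the weakening direction and reached that limit.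

Compound 3 `O=C(O)/C=C/c1ccc(OCc2ccccc2)cc1OCCc1ccc2ccccc2c1` differs from compound 2 by benzyloxy in place of phenoxymethyl on an aromatic carbon. The two compounds share every atom and differ only in how the oxygen and the chain carbon are arranged at that position. Among the compounds with values here, no measured step here covers such a rearrangement; the single step between compound 1 and compound 2 exchanged one whole group for another and so speaks only indirectly, by showing that this part of the core is sensitive to what hangs there. For compound 3 the expected outcome is therefore a number close to that of compound 2, a step that the limit leaves unreadable from compound 2 to compound 3, most likely again at or near the limit of this assay. Compound 3 is estimated at 12000 nM, with a range from 4000 nM to 40000 nM.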

Compound 3, inhibition constant: > 10000 nM
Compound 3 was reported as a limit (the forecaster's own chance of this, stated with the estimate: 55%); the middle value does not contradict the limit.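

In this assay compound 3 gives > 10000 nM, which is a limit of the assay and not a number. At the aromatic carbon para to the 2-carboxyethenyl group, benzyloxy in place of (1H-pyrazol-1-yl)methyl gives an at least 3.4-fold higher number from compound 1 to compound 3 (0.53 log units; beyond the scatter), so a second group carrying an unsubstituted benzene ring now falls short of compound 1, which remains the strongest of the three. Swapping the oxygen and the chain carbon brings no value back into the readable range, and the step between the two rearranged compounds cannot be read, while the limit now holds most of the series: the limit of > 10000 nM in this assay, at which 2 of the 3 values shown sit.

Going by these compounds, how far compound 2 and compound 3 lie beyond that limit, and whether they differ from each other at all, stays open. Also open, on these data alone, is whether a group other than these three, such as an aminomethyl group, an imidazol-1-ylmethyl group or a pyrazole on a longer chain, would match compound 1 at this position or improve on it.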